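Swapping an isopropyl for a benzyl on the aryl ether oxygen

The source may hold more compounds than are shown below. What is called first, only, known or untested is meant among the compounds shown, and "the series" means these compounds.

Of the compounds shown here, three sharing one core have been measured in an assay on cells for antagonist activity at transient receptor potential cation channel subfamily V member 1 (Homo sapiens), read by FLIPR and calcium flux, with a stated time of 6 min; on this read-out lower numbers stand for stronger inhibition and higher numbers for weaker inhibition. Compound 1 `CC(C(=O)NCc1ccc(C(C)(C)C)nc1N1CCCCCC1)c1ccc(NS(C)(=O)=O)c(F)c1` gives 0.9 nM. Compound 2 `CCCOc1nc(C(C)(C)C)ccc1CNC(=O)C(C)c1ccc(NS(C)(=O)=O)c(F)c1` gives 1.7 nM, and compound 3 `CC(C)Oc1nc(C(C)(C)C)ccc1CNC(=O)C(C)c1ccc(NS(C)(=O)=O)c(F)c1` gives 2.3 nM. Compound 3 therefore has the highest of the three numbers: the step of a 2.6-fold higher number from compound 1 to compound 3 (0.41 log units; beyond the scatter) is beyond the scatter, whereas the steps of a 1.9-fold higher number from compound 1 to compound 2 (0.28 log units; within the scatter) and a 1.4-fold higher number from compound 2 to compound 3 (0.13 log units; within the scatter) are not.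

Compound 4 `CC(C(=O)NCc1ccc(C(C)(C)C)nc1OCc1ccccc1)c1ccc(NS(C)(=O)=O)c(F)c1` is the next candidate. It differs from compound 3 by benzyl in place of isopropyl on an oxygen on an aromatic ring. Among the measured compounds shown here, the only measured step that touches the same oxygen is a 1.4-fold higher number from compound 2 to compound 3 (0.13 log units; within the scatter), where one small alkyl group replaced another and the number barely moved. For the measured compounds named here, no measured step introduces an aromatic ring at that place, so the benzyl group reaches beyond what the data cover.

Given the small movement seen in a 1.4-fold higher number from compound 2 to compound 3 (0.13 log units; within the scatter), the expected step in this assay is a 1.5-fold higher number from compound 3 to compound 4 (0.18 log units; within the scatter), slight and within the scatter. Compound 4 is therefore estimated at 3.5 nM, with a likely range from 1.2 nM to 12 nM.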

Compound 4, inhibition constant: 4.4 nM
Beside the measured number, compound 4's estimate is 1.3-fold (0.10 log units) below it; the measured number falls inside the stated range.
By their numbers in this assay, from the lowest: compounds 1, 2, 3 and 4 (each within the scatter of the next, the first and the last beyond it).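

An aromatic ring can sit on this oxygen with no clear loss: benzyl in place of isopropyl gives a step within the scatter (a 1.9-fold higher number from compound 3 to compound 4 (0.28 log units; within the scatter)). The picture changes against the straight-chain ether, where the step from the propyl group lies beyond the scatter, though only modestly (a 2.6-fold higher number from compound 2 to compound 4 (0.41 log units; beyond the scatter)). Benzyloxy in place of azepan-1-yl gives the largest step of the set, also modest and beyond the scatter (a 4.9-fold higher number from compound 1 to compound 4 (0.69 log units; beyond the scatter)), so a nitrogen-linked ring and an oxygen-linked benzyl group are not interchangeable at this place on the shared core. No measurement shown explains why these numbers differ. Still open, on these data alone, is how a phenyl group placed directly on the oxygen would compare with benzyl. Also open, as far as these compounds go, is whether an amine or a carboxylic acid on the benzyl ring would keep the number in this range.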